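Aryl swap on the pyridazinone nitrogen and cytotoxicity

A few compounds are considered here, and "the series" means these few. Any claim that something is new, unique, unknown or untested is made for them only; others in the source may bear on it.

Compound 1: `Cc1cc(=O)n(-c2ccccc2C(F)(F)F)nc1C(=O)Nc1ccc(Oc2ncnc3sccc23)c(F)c1` gives 14700 nM
Compound 2: `Cc1cc(=O)n(-c2cccc(F)c2)nc1C(=O)Nc1ccc(Oc2ncnc3sccc23)c(F)c1` gives 24500 nM

In a functional assay on HepG2 cells (Homo sapiens) for cytotoxicity, read by MTT assay, with a stated time of 72 h (on this read-out lower numbers stand for stronger inhibition and higher numbers for weaker inhibition), compound 2 gives the higher of the two numbers, with compound 1 as its nearest neighbour; the step of a 1.7-fold higher number from compound 1 to compound 2 (0.22 log units; within the scatter) lies within the scatter. Compound 3 `Cc1ccc(-n2nc(C(=O)Nc3ccc(Oc4ncnc5sccc45)c(F)c3)c(C)cc2=O)cc1` differs from compound 2 by 4-methylphenyl in place of 3-fluorophenyl on an aromatic nitrogen. Among the measured compounds shown here, no measured step touches a 4-methylphenyl group here, and the only aryl exchange known, that from compound 1 to compound 2, stayed within the scatter. Compound 3 is therefore expected to sit close to compound 2, with the step of a 1.1-fold lower number from compound 2 to compound 3 (0.05 log units; within the scatter) not beyond the scatter. For compound 3 the estimate in this assay is 22000 nM, between 8000 nM and 60000 nM.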

Compound 3, half-maximal inhibitory concentration: > 40000 nM
Compound 3: a limit, no number; the forecaster's own chance of this, stated with the estimate: 10%; middle value at least 1.8-fold (0.25 log units) away from the limit.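

In this assay compound 3 carries a limit and not a number: the limit of > 40000 nM in this assay, at which 1 of the 3 values shown sits.

Placing 4-methylphenyl on the aromatic nitrogen gives an at least 2.7-fold higher number from compound 1 to compound 3 (0.43 log units; beyond the scatter), the only aryl exchange shown that passes beyond the scatter, while an at least 1.6-fold higher number from compound 2 to compound 3 (0.21 log units; that floor lies within the scatter) has a floor that stays within it. The aryl group at this position can therefore change the read-out, which the earlier pair did not show.

Left open are how far past its limit compound 3 lies and whether an amine or a carboxylic acid on this aryl group would lower the number.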